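Amide substituent variation: from cyclopropyl to phenethyl

The compounds below may be only part of what the source reports. "The series", "measured", "known", "first", "only" and "open" are said of these compounds alone.

Measured so far:
- compound 1 `CCCC(=O)Nc1c(C(O)(C(F)(F)F)C(F)(F)F)ccc2ccccc12` gives 131 nM in an assay on LtK cells with ATP-sensitive inward rectifier potassium channel 11 (Homo sapiens) as the target; on this read-out lower numbers stand for an effect already at smaller amounts and higher numbers for an effect only at larger amounts of compound
- compound 2 `CC(C)=CC(=O)Nc1c(C(O)(C(F)(F)F)C(F)(F)F)ccc2ccccc12` gives 46 nM in this assay
- compound 3 `O=C(Nc1c(C(O)(C(F)(F)F)C(F)(F)F)ccc2ccccc12)C1CC1` gives 751 nM in this assay

Compound 3 stands at the highest number of the three. The steps of a 5.7-fold higher number from compound 1 to compound 3 (0.76 log units; beyond the scatter) and a 16-fold higher number from compound 2 to compound 3 (1.21 log units; beyond the scatter) both run upward and both lie beyond the scatter, so on the shared core the cyclopropyl amide is the one that needs the most compound.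

Compound 4 `O=C(CCc1ccccc1)Nc1c(C(O)(C(F)(F)F)C(F)(F)F)ccc2ccccc12` differs from compound 3 by phenethyl in place of cyclopropyl on a carbonyl carbon. The two measured steps that bear on this change are the ones into compound 3, read in reverse: a 5.7-fold higher number from compound 1 to compound 3 (0.76 log units; beyond the scatter) and a 16-fold higher number from compound 2 to compound 3 (1.21 log units; beyond the scatter) show that replacing the three-membered ring by a chain on the carbonyl carbon lowers the number, by a modest amount for propyl and by a large one for 2-methylprop-1-en-1-yl. Phenethyl is again a chain on that carbon, so a downward step in this assay is expected, of modest to large size, a 6.8-fold lower number from compound 3 to compound 4 (0.83 log units; beyond the scatter). Among the measured compounds shown here, no measured compound carries an aromatic ring on the amide side, so the size is uncertain and the range is kept wide. Compound 4 is estimated at 110 nM, within 30 nM to 450 nM.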

Compound 4, half-maximal effective concentration: 1750 nM
Compound 4: the middle estimate sits 16-fold (1.20 log units) below what was measured; the measured number lies above the stated range.
By their numbers in this assay, from the lowest: compound 2; then compound 1; then compound 3; then compound 4.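

In this assay a chain on the carbonyl carbon does not by itself bring the number down: a 2.3-fold higher number from compound 3 to compound 4 (0.37 log units; beyond the scatter) and so phenethyl goes against the direction seen with propyl and 2-methylprop-1-en-1-yl, leaving compound 4 with the highest number of the four. The closest comparison is phenyl in place of methyl on a saturated chain carbon, two bonds along the chain from a carbonyl carbon, which gives a 13-fold higher number from compound 1 to compound 4 (1.13 log units; beyond the scatter) and shows that extending the propyl chain with this ring carries a large penalty here, while the distance to the 2-methylprop-1-en-1-yl amide grows to a 38-fold higher number from compound 2 to compound 4 (1.58 log units; beyond the scatter) on the same core. Nothing measured on these compounds accounts for the size of this penalty.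

Still open, from the compounds shown here alone, is whether the upward step belongs to the phenyl ring or to chain length, a question that a pentyl chain or a phenyl directly on the carbonyl carbon would separate. Also open, going by these compounds, is how the position responds to a cyclohexyl ring, or to an amine or a carboxylic acid at the end of the chain.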